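The compounds below may be only part of what the source reports. "The series", "measured", "known", "first", "only" and "open" are said of these compounds alone.

Measured compounds in a functional assay on the whole organism for inhibition, with Rattus norvegicus as the target, read by paw edema; on this read-out lower numbers stand for an effect already at smaller amounts and higher numbers for an effect only at larger amounts of compound:
compound 1 `O=C(O)c1cc(-c2ncccn2)ccc1O`, which gives 100 mg/kg in this assay;
compound 2 `O=C(O)c1cc(-c2c[nH]cn2)ccc1O`, which gives 100 mg/kg in this assay;
compound 3 `O=C(O)c1ccc(-c2ncco2)cc1O`, for which this assay reports only a limit, > 250 mg/kg.

Compound 2 stands level with compound 1 at the digits given, within the scatter of this assay. Among the measured compounds shown here, the only other value is a limit, (the limit of > 250 mg/kg in this assay, at which 1 of the 3 values shown sits), so no measured step between two compounds is available to calibrate a change of the heteroaryl group. Compound 4 `O=C(O)c1cc(-n2cncn2)ccc1O` differs from compound 2 by 1H-1,2,4-triazol-1-yl in place of 1H-imidazol-4-yl on an aromatic carbon. With nothing to anchor this change, the step from compound 2 to compound 4 is expected to be small, a 1.2-fold higher number from compound 2 to compound 4 (0.08 log units; within the scatter), and to stay within the scatter. Compound 4 is therefore estimated at 120 mg/kg in this assay, with a range from 50 mg/kg to 250 mg/kg.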

Compound 4, dose for half-maximal effect: 200 mg/kg
The estimate for compound 4 lay 1.7-fold (0.22 log units) below the measured number; low and high end bracket the measured number.
By their numbers in this assay, from the lowest: compounds 1, 2 and 4 (each within the scatter of the next). At a limit, above all of these: compound 3.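

Among the compounds shown here, compound 4 gives the first readable step at this position, para to the hydroxy group and meta to the carboxy group: in this assay, the change shows a 2.0-fold higher number from compound 2 to compound 4 (0.30 log units; within the scatter). The triazolyl group, unlike the imidazolyl group it replaces, has no hydrogen-bond donor, yet the step stays within the scatter. Nothing measured here explains this outcome.

From the compounds shown here alone, whether a group other than an aromatic ring, such as an amine or a carboxylic acid, would shift the number at this carbon remains open.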